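The compounds below may be only part of what the source reports. "The series", "measured", "known", "first", "only" and "open" are said of these compounds alone.

Compounds measured in a functional assay on isolated protein for agonist activity at Glucose-dependent insulinotropic receptor (Homo sapiens), read by HTRF and cAMP accumulation; a lower number here means that less compound is needed, a higher number that more compound is needed for the effect:
- compound 1 `C[C@H](CF)OC(=O)N1CCC(O[C@H]2CC[C@H](Oc3cnc(S(C)(=O)=O)cn3)CC2)CC1` gives 36.8 nM
- compound 2 `CS(=O)(=O)c1cnc(O[C@H]2CC[C@H](OC3CCN(C(=O)C4(C(F)(F)F)CC4)CC3)CC2)cn1` gives 107 nM

Compound 2 holds the highest number of the two in this assay; its nearest neighbour is compound 1, and the gap is a 2.9-fold higher number from compound 1 to compound 2 (0.46 log units; beyond the scatter). Within the data shown here, that one step is the whole record of the series so far and it concerns the group on the carbonyl carbon only.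

Compound 3 `CS(=O)(=O)c1cnc(O[C@H]2CC[C@H](OC3CCN(CC4(C(F)(F)F)CCCC4)CC3)CC2)cn1` is the next case. The change from compound 2 is a group of 10 heavy atoms (7 carbon, 3 fluorine; one five-membered non-aromatic ring of carbon only) in place of a group of 9 heavy atoms (5 carbon, 1 oxygen, 3 fluorine; one three-membered non-aromatic ring of carbon only), on an amine nitrogen in a ring. The carbonyl itself leaves with the group, so the measured step from compound 1 to compound 2 does not cover this kind of change; it only shows that changing what sits at this end of the molecule moved the number by a modest amount. Among the measured compounds shown here, no other step bears on it.

On that basis compound 3 is expected to show a 2.3-fold higher number from compound 2 to compound 3 (0.37 log units; beyond the scatter), a step of roughly the size already seen at this end of the molecule and more likely upward than downward. The estimate for compound 3 is 250 nM, with a range from 70 nM to 900 nM.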

Compound 3, half-maximal effective concentration: 48.8 nM
The estimate for compound 3 lay 5.1-fold (0.71 log units) above the measured number; the whole stated range lies above it.
By their numbers in this assay, from the lowest: compounds 1 and 3 (each within the scatter of the next); then compound 2.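

In this assay, the amine nitrogen in the ring no longer has to carry a carbonyl: both earlier compounds have one there, and the group without it gives a 2.2-fold lower number from compound 2 to compound 3 (0.34 log units; beyond the scatter) in the series. That step changes two things at once, since the carbonyl leaves and a five-membered carbon ring replaces a three-membered one, so it cannot be assigned to either change alone. The comparison with the ringless carbamate-type end of compound 1 shows a 1.3-fold higher number from compound 1 to compound 3 (0.12 log units; within the scatter) and so places two very different groups at this nitrogen with no separation in the number, which widens what this position accepts beyond what the first pair showed.

Still open is which of the two changes accounts for the step, and a (1-(trifluoromethyl)cyclopentyl)carbonyl group on the same nitrogen would separate them. Also open, going by these compounds, is what the trifluoromethyl contributes on the five-membered ring, for which a methyl group in its place would be the direct comparison. No measurement at hand offers an explanation for any of these steps in the series.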